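The compounds below may be only part of what the source reports. "The series", "measured", "known", "first", "only" and "open" are said of these compounds alone.

Measured compounds:
compound 1 `COc1cccc(/C=C2\CCC/C(=C\c3ccccc3Cl)C2=O)c1OC`: 11700 nM
compound 2 `COc1cccc(/C=C2\CCC/C(=C\c3cccc(Cl)c3)C2=O)c1OC`: 10300 nM
compound 3 `COc1cccc(/C=C2\CCC/C(=C\c3cccc(O)c3)C2=O)c1OC`: 8500 nM

In a functional assay on HT-1080 cells (Homo sapiens) for cytotoxicity, read by MTT assay, with a stated time of 72 h (a lower number here means a stronger inhibitor, a higher number a weaker inhibitor), compound 2 gives 10300 nM, the second highest of the three numbers. The steps of a 1.1-fold lower number from compound 1 to compound 2 (0.06 log units; within the scatter) and a 1.2-fold lower number from compound 2 to compound 3 (0.08 log units; within the scatter) are both within the scatter, as is a 1.4-fold lower number from compound 1 to compound 3 (0.14 log units; within the scatter), so the three measured compounds are not separated from one another in this assay.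

Compound 4 `COc1cccc(/C=C2\CCC/C(=C\c3cccc(Cl)c3Cl)C2=O)c1OC` differs from compound 2 by chloro in place of hydrogen on an aromatic carbon. Going by the values given here, no measured step adds a second substituent to this ring; the measured steps only move or exchange a single group, and none reached beyond the scatter. No step beyond the scatter is therefore expected here either. Compound 4 is estimated at 8000 nM in this assay, within 3500 nM to 18000 nM, which means an expected step of a 1.3-fold lower number from compound 2 to compound 4 (0.11 log units; within the scatter).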

Compound 4, half-maximal inhibitory concentration: 19300 nM
The estimate for compound 4 lay 2.4-fold (0.38 log units) below the measured number, and the stated range ends below it.
By their numbers in this assay, from the lowest: compounds 3, 2, 1 and 4 (each within the scatter of the next, the first and the last beyond it).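

In this assay the added chloro on the 3-chlorophenyl ring gives a 1.9-fold higher number from compound 2 to compound 4 (0.27 log units; within the scatter) and the added chloro on the 2-chlorophenyl ring gives a 1.6-fold higher number from compound 1 to compound 4 (0.22 log units; within the scatter) so the 2,3-dichlorophenyl ring is not separated from either single-chloro ring. Going by these compounds alone, the first step beyond the scatter, modest in size, is a 2.3-fold higher number from compound 3 to compound 4 (0.36 log units; beyond the scatter) and it sets the 2,3-dichlorophenyl ring against the 3-hydroxyphenyl ring. Nothing at hand accounts for this step.

From the compounds shown here alone, whether an amine or a carboxylic acid on this ring would give a larger step remains open.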